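The source may report more compounds than this note shows. Statements on the series, on what has been measured and on what is new or still open speak of the compounds shown alone.

Measured so far in a functional assay on HeLa cells (Homo sapiens) for antiproliferative activity, read by sulforhodamine B assay, with a stated time of 48 h; a higher number here means a weaker inhibitor, a lower number a stronger inhibitor:
compound 1, `COc1cc(OC)c2sc(-c3ccc(N/C=C\C(=O)c4cc(OC)c(OC)c(OC)c4)cc3)nc2c1` — 17800 nM
compound 2, `COc1ccc(C(=O)/C=C\Nc2ccc(-c3nc4cc(OC)c(OC)c(OC)c4s3)cc2)cc1[N+](=O)[O-]` — 11400 nM
compound 3, `COc1ccc(C(=O)/C=C\Nc2ccc(-c3nc4cc(OC)c(OC)c(OC)c4s3)cc2C)cc1O` — 11400 nM

Compound 1 carries the highest number of the three, but the numbers of compound 2 and compound 3 lie within the scatter of it, so nothing can be said about order among these three; all three sit at the weak end of the read-out. Compound 2 and compound 3 share with compound 1 the same enone linker and the same general arrangement, with other substitution on the ring attached to the carbonyl, and on that ring the values show no difference beyond the scatter.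

Compound 4, `COc1cc(OC)c2sc(-c3ccc(N/C=C\C(=O)c4ccc(OC)c(F)c4)cc3)nc2c1`, is not yet measured. Relative to compound 1 the change is 3-fluoro-4-methoxyphenyl in place of 3,4,5-trimethoxyphenyl on a carbonyl carbon. For the measured compounds named here, the only guidance is that compound 2 and compound 3, which also carry a 4-methoxyphenyl ring with a single further substituent at the carbonyl, give values within the scatter of compound 1. The step of a 1.5-fold lower number from compound 1 to compound 4 (0.17 log units; within the scatter) is therefore expected to be small, at most a slight lowering, and not beyond the scatter. Compound 4 is estimated at 12000 nM, with a range of 4000 nM to 40000 nM.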

Compound 4, half-maximal inhibitory concentration: 7300 nM
Compound 4: the middle estimate sits 1.6-fold (0.22 log units) above what was measured; measured number inside the range.
By their numbers in this assay, from the lowest: compounds 4, 2, 3 and 1 (each within the scatter of the next, the first and the last beyond it).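

In this assay, for the compounds shown here, a 2.4-fold lower number from compound 1 to compound 4 (0.39 log units; beyond the scatter) is the first comparison that changes only one place, and it shows that the aryl group on the carbonyl carbon can move the number beyond the scatter, which compound 2 and compound 3 could not show, as neither is a single-place change from compound 1. The 3,4,5-trimethoxyphenyl group is therefore not required to hold this level of antiproliferative activity, since 3-fluoro-4-methoxyphenyl, with fewer heavy atoms and fewer hydrogen-bond acceptors, gives a lower number, though the step is modest. No measurement here bears on why the number falls with this change.

From the compounds shown here alone, this single replacement both adds fluorine and removes methoxy groups, so which of these carries the step remains open, and a 4-methoxyphenyl ring with chlorine or a nitrile in place of the fluorine would help to separate them. Also open, going by these compounds, is whether an aryl group carrying an amine or a carboxylic acid on the same carbonyl carbon would move the number further from the weak end of the read-out, where compound 4 at 7300 nM still sits.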